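A Biaryl Replaces Bromine at the Top of the Series

A few compounds are considered here, and "the series" means these few. Any claim that something is new, unique, unknown or untested is made for them only; others in the source may bear on it.

Of the compounds shown here, three have been measured in a functional assay on 1321-N1 cells for agonist activity at Free fatty acid receptor 1 (Homo sapiens), read by calcium flux; on this read-out lower numbers stand for smaller maximal responses and higher numbers for larger maximal responses. Compound 1 `O=C(O)CCc1ccc(OCc2ccccc2)c(I)c1` gives 81%, compound 2 `O=C(O)CCc1ccc(OCc2ccccc2Br)cc1` gives 99%, and compound 3 `O=C(O)CCc1ccc(NCc2cccc(Br)c2)cc1` gives 110%. Compound 3 therefore stands highest of the three, and its gaps to compound 2 and to compound 1 both lie beyond the usual scatter.

Compound 4 `COc1ccccc1-c1cccc(CNc2ccc(CCC(=O)O)cc2)c1` keeps the core of compound 3 and differs from it in one place: 2-methoxyphenyl in place of bromo on an aromatic carbon. Going by the values given here, no two measured compounds differ in a single place, so no measured step guides this change. The step in this assay is expected to be a number 10 percentage points lower from compound 3 to compound 4 (within the scatter), a small decrease or none beyond the scatter. Compound 4 is estimated at 100%, within a range from 80% to 120%.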

Compound 4, largest response reached (reported as efficacy), in percent of the reference or control that the assay uses: 109%
The estimate for compound 4 lay 9 percentage points below the measured number; the measured number falls inside the stated range.
By their numbers in this assay, from the lowest: compound 1; then compounds 2, 4 and 3 (each within the scatter of the next, the first and the last beyond it).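

In this assay, 2-methoxyphenyl in place of bromo gives a number 1 percentage points lower from compound 3 to compound 4 (within the scatter), so the two compounds cannot be told apart. Going by these compounds alone, this is the first single-place comparison, and it shows that this aromatic carbon, meta to a large group, accepts a group of 8 heavy atoms with its own aromatic ring in place of a single bromine without a separable change in maximal response. Nothing available here bears on the reason for this result. The compounds shown leave open whether the methoxy group matters, which a plain phenyl at this place would test. They also leave open how a more compact group, such as methyl or chloro, would compare.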